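Swapping the Group on a Ring Nitrogen: Still Flat Expected

The source may hold more compounds than are shown below. What is called first, only, known or untested is meant among the compounds shown, and "the series" means these compounds.

Measured so far:
compound 1, `Nc1scc(CN2CCN(c3cc(Cl)cc(Cl)c3)CC2)c1C(=O)c1ccc(Cl)cc1`: 1%
compound 2, `Nc1scc(CN2CCN(c3ccc(F)cc3Cl)CC2)c1C(=O)c1ccc(Cl)cc1`: 0%
compound 3, `Nc1scc(CN2CCN(c3ccccc3F)CC2)c1C(=O)c1ccc(Cl)cc1`: 0%

All three compounds share one core and differ only in the aromatic group attached to a ring nitrogen. In an assay on CHO cells for displacement of a labelled ligand from adenosine receptor A3 (Homo sapiens), read by scintillation counting, with a stated time of 120 min, tested at 10 uM (on this read-out higher numbers stand for more inhibition at the one concentration tested (going by the name of the read-out) and lower numbers for less inhibition), compound 1 gives 1%, compound 2 gives 0% and compound 3 gives 0%. Compound 3 stands level with compound 2 at the digits shown, the two together the lowest of the three, and compound 1 is only slightly higher: a number 1 percentage points lower from compound 1 to compound 3 (within the scatter), which lies within the scatter. Every measured step here, a number 1 percentage points lower from compound 1 to compound 2 (within the scatter) and no change at the digits printed from compound 2 to compound 3 (within the scatter) included, stays within the scatter, so changing one aromatic group for another on that nitrogen has so far made no visible difference.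

Compound 4, `Nc1scc(CN2CCN(CCCc3ccc(Cl)cc3)CC2)c1C(=O)c1ccc(Cl)cc1`, is not yet measured. It differs from compound 3 in one place: 3-(4-chlorophenyl)propyl in place of 2-fluorophenyl on an amine nitrogen in a ring. The three measured steps all exchange one aromatic ring for another directly on the nitrogen, so they bear on this step only loosely; none puts a chain between the nitrogen and the ring. Going by the values given here, with no measured step moving beyond the scatter, the expectation is a number 2 percentage points higher from compound 3 to compound 4 (within the scatter), that is, no change beyond the scatter. Compound 4 is therefore estimated at 2%, within a range of -6% to 18%.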

Compound 4, a percentage reported as inhibition, at one concentration (the size of the read-out at that concentration, not a potency): 0%
Compound 4: middle estimate off by 2 percentage points, on the high side, within the range that was stated.
By their numbers in this assay, from the lowest: compounds 2, 3, 4 and 1 (each within the scatter of the next).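

In this assay, the new step does something the earlier ones did not: it puts a chain between the ring nitrogen and the aromatic ring, yet the read-out stays flat, with no change at the digits printed from compound 3 to compound 4 (within the scatter), no change at the digits printed from compound 2 to compound 4 (within the scatter) and a number 1 percentage points lower from compound 1 to compound 4 (within the scatter). This position has now carried aromatic rings attached directly and the 3-(4-chlorophenyl)propyl group, which has 10 heavy atoms against the 7 of 2-fluorophenyl, with no difference beyond the scatter. No supporting measurement is available to explain this flat result.

Both 2-fluorophenyl and 3-(4-chlorophenyl)propyl have one aromatic ring, no hydrogen-bond donors or acceptors and no net charge, so the compounds shown leave open what an amine, a carboxylic acid or a longer chain on that nitrogen would do. From the compounds shown here alone, the rest of the shared core is the same in all four compounds, so it also remains open whether a change elsewhere, such as replacing the chlorine on the 4-chlorophenyl ketone with a methoxy group, would move the number.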